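A methyl group added to a sulfonylurea at the limit

The source may report more compounds than this note shows. Statements on the series, on what has been measured and on what is new or still open speak of the compounds shown alone.

Measured in a functional assay on thoracic aorta (Rattus norvegicus, strain Wistar), with a stated time of 15 min; a lower number here means that less compound is needed, a higher number that more compound is needed for the effect:
- compound 1 `CCOc1ccc(F)cc1C(C)NC(=O)NS(=O)(=O)c1ccc(C)cc1` gives > 300000 nM (a limit)
- compound 2 `CCOc1ccc(Br)cc1C(C)NC(=O)NS(=O)(=O)c1ccccc1` gives > 300000 nM (a limit)
- compound 3 `CC(NC(=O)NS(=O)(=O)c1ccccc1)c1cc(Br)ccc1OCc1ccccc1` gives 130000 nM

Compound 2 has no number in this assay, only a limit. The same is true of compound 1, and the limit of > 300000 nM in this assay, at which 2 of the 3 values shown sit, shows how little of the scale the series has reached so far. Compound 4 `CCOc1ccc(Br)cc1C(C)NC(=O)NS(=O)(=O)c1ccc(C)cc1` differs from compound 2 by a methyl in place of hydrogen on an aromatic carbon, turning phenyl into 4-methylphenyl (methyl in place of hydrogen on an aromatic carbon).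

Among the measured compounds shown here, the one measured step, an at least 2.3-fold lower number from compound 2 to compound 3 (0.36 log units; beyond the scatter), changes a different part of the molecule and says little about this change. The closest guide is compound 1, which already carries the 4-methylphenyl group and gives > 300000 nM, which is a limit. No step beyond the scatter is therefore expected in this assay, and compound 4 will probably also report only a limit. The estimated step is a number no higher from compound 2 to compound 4 (the limit leaves the size open). For compound 4 the expected value is 300000 nM, with an estimated range from 120000 nM to 500000 nM.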

Compound 4, half-maximal effective concentration: > 300000 nM
Compound 4 ended at the assay's limit (the forecaster's own chance of this, stated with the estimate: 65%); the middle value lies on the limit itself.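

In this assay compound 4 gives > 300000 nM, which is a limit and not a number. Its steps from compound 1 and from compound 2, which also sit at limits, cannot be read. The compounds shown leave open whether 4-methylphenyl in place of phenyl, or bromo in place of fluoro, changes the number at all.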